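The source may hold more compounds than are shown below. What is called first, only, known or untested is meant among the compounds shown, and "the series" means these compounds.

Measured in a functional assay for agonist activity at Free fatty acid receptor 1 (Homo sapiens), read by FLIPR, in the presence of a further agent that is not named here; on this read-out lower numbers stand for an effect already at smaller amounts and higher numbers for an effect only at larger amounts of compound:
compound 1 `Cc1cccc(Oc2ccc(CC3SC(=O)NC3=O)cc2)c1` gives 203 nM
compound 2 `COc1cc(Oc2ccc(Cl)cc2Cl)ccc1CC1SC(=O)NC1=O` gives 1410 nM
compound 3 `Cc1ccc(Oc2ccc(CC3SC(=O)NC3=O)cc2)cc1` gives 547 nM

Compound 2 stands highest of the three numbers in this assay; compound 3 lies nearest to it and compound 1 furthest, both gaps beyond the scatter. Going by the values given here, the one step measured, a 2.7-fold higher number from compound 1 to compound 3 (0.43 log units; beyond the scatter), concerns where the methyl sits on the ring attached through the oxygen, not the ring that carries the thiazolidinedione side chain.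

Compound 4 `O=C1NC(=O)C(Cc2ccc(Oc3ccc(Cl)cc3Cl)cc2)S1` differs from compound 2 in a single place: hydrogen in place of methoxy on an aromatic carbon. Among the compounds with values here, no measured pair isolates this change. Compounds 1 and 3 also lack a methoxy on that ring, and both give lower numbers than compound 2, but they differ from compound 4 in the other ring as well, so their values cannot be read as a measure of the methoxy alone. The step from compound 1 to compound 3 does not bear on the change either.

With nothing that speaks for a direction, the working expectation for compound 4 is a number in the region of compound 2, with a wide range to either side; the expected step is a 1.8-fold lower number from compound 2 to compound 4 (0.25 log units; within the scatter). The estimate for compound 4 is 800 nM, between 200 nM and 3000 nM.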

Compound 4, half-maximal effective concentration: 101 nM
Beside the measured number, compound 4's estimate is 7.9-fold (0.90 log units) above it, outside the stated range (below it).
By their numbers in this assay, from the lowest: compounds 4 and 1 (each within the scatter of the next); then compound 3; then compound 2.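

In this assay, going by these compounds alone, a 14-fold lower number from compound 2 to compound 4 (1.14 log units; beyond the scatter) is the first measured step at this aromatic carbon, ortho to the (2,4-dioxo-1,3-thiazolidin-5-yl)methyl group, and it is large and beyond the scatter. This pair ties the high number of compound 2 to the methoxy itself, since the other ring stays unchanged, and compound 4 at 101 nM shows that the ring bearing two chlorines does not by itself keep the number high. The position therefore responds strongly to this change, and the step is larger than the only other one in the series, a 2.7-fold higher number from compound 1 to compound 3 (0.43 log units; beyond the scatter), but nothing available explains the size of the methoxy effect.

Open, from the compounds shown here alone, is whether a fluorine, a methyl or a hydroxyl on this aromatic carbon would give a number closer to that of compound 4 or that of compound 2, which would show how much of the step follows from the methoxy in particular. Within the data shown here, also open is whether a methoxy at the same carbon would produce a step of similar size alongside the methyl-bearing rings of compound 1 and compound 3, as the single pair speaks only for the ring with two chlorines.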